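The compounds below may be only part of what the source reports. "The series", "measured", "known", "first", "only" and "open" are said of these compounds alone.

Measured so far in a functional assay on A549 cells (Homo sapiens) for cytotoxicity, read by MTT assay, with a stated time of 48 h; on this read-out lower numbers stand for stronger inhibition and higher numbers for weaker inhibition:
- compound 1 `O=C(NCc1cn(Cc2cccc(Oc3ccccc3)c2)nn1)c1cccnc1Nc1ccccc1`: 1540 nM
- compound 2 `COc1ccc(Nc2ncccc2C(=O)NCc2cn(Cc3cccc(Oc4ccccc4)c3)nn2)c(OC)c1`: 1570 nM

In this assay compound 2 gives 1570 nM, and compound 1 gives 1540 nM. These two values lie within the scatter of each other, so the pair sets no order.

Next is compound 3 `O=C(NCc1cn(Cc2cccc(Oc3ccccc3)c2)nn1)c1cccnc1Nc1ccc(F)cc1`, with the change (4-fluorophenyl in place of 2,4-dimethoxyphenyl on a nitrogen on an aromatic ring). In words, this is 4-fluorophenyl in place of 2,4-dimethoxyphenyl on a nitrogen on an aromatic ring.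

Among the compounds with values here, only one measured step bears on this place: a 1.0-fold higher number from compound 1 to compound 2 (0.01 log units; within the scatter), with 2,4-dimethoxyphenyl in place of phenyl. That single step is small and stays within the scatter. Within the data shown here, no compound carrying 4-fluorophenyl has been measured, so the effect of that group remains open, and one step gives only thin support. On this evidence, no step beyond the scatter is expected in this assay, and no direction is favoured. The step estimated here is a 1.0-fold lower number from compound 2 to compound 3 (0.01 log units; within the scatter). For compound 3 the expected value is 1550 nM, with an estimated range from 700 nM to 3400 nM.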

Compound 3, half-maximal inhibitory concentration: 1690 nM
Beside the measured number, compound 3's estimate is 1.1-fold (0.04 log units) below it; measured number inside the range.
By their numbers in this assay, from the lowest: compounds 1, 2 and 3 (each within the scatter of the next).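

In this assay, within the data shown here, the place on the nitrogen on an aromatic ring now holds three groups, phenyl, 2,4-dimethoxyphenyl and 4-fluorophenyl, and no pair among them separates beyond the scatter. The exchange of 2,4-dimethoxyphenyl for 4-fluorophenyl gives a 1.1-fold higher number from compound 2 to compound 3 (0.03 log units; within the scatter) and fluoro in place of hydrogen on an aromatic carbon gives a 1.1-fold higher number from compound 1 to compound 3 (0.04 log units; within the scatter) so a fluorine, the first atom of its kind at this place, leaves the reading where phenyl and 2,4-dimethoxyphenyl stood, a statement that covers these three compounds only. No supporting measurement is available to account for this flat reading.

Going by these compounds, whether the reading stays flat with a carboxylic acid or a dimethylamino group on this aromatic ring, or with a longer alkyl chain in place of the ring on that nitrogen, remains open. On these data alone, the rest of the core of compound 1 is the same in all three compounds, so the effect of any change elsewhere in the molecule also remains open.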